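This account rests on a few compounds, and the source may have more. Where it says the series, first, only, none or still open, it means among the compounds named here.

Compound 1 `N#CC1=C(NC(=O)C2CC2)N(c2ccc(S(N)(=O)=O)cc2)C2=C(C(=O)CCC2)C1c1ccc(Cl)cc1Cl`, compound 2 `Cc1ccc(C(=O)NC2=C(C#N)C(c3ccc(Cl)cc3Cl)C3=C(CCCC3=O)N2c2ccc(S(N)(=O)=O)cc2)cc1` and compound 3 `N#CC1=C(NC(=O)/C=C/c2ccccc2)N(c2ccc(S(N)(=O)=O)cc2)C2=C(C(=O)CCC2)C1c1ccc(Cl)cc1Cl` share one core and differ only in the group on the amide carbonyl carbon. In a functional assay on Ehrlich cells (Mus musculus) for cytotoxicity, read by trypan blue exclusion, with a stated time of 2 h, tested at 100 ug/mL (a lower number here means a weaker effect, a higher number a stronger effect of the compound at the concentration tested), compound 1 gives 60%, compound 2 gives 40% and compound 3 gives 45%. Compound 3 stands second highest of the three numbers; its nearest neighbour is compound 2, within the scatter, and its furthest is compound 1, beyond the scatter. Both aromatic replacements of cyclopropyl lowered the read-out, as seen in a number 20 percentage points lower from compound 1 to compound 2 (beyond the scatter) and a number 15 percentage points lower from compound 1 to compound 3 (beyond the scatter), while the exchange between the two aromatic groups, a number 5 percentage points higher from compound 2 to compound 3 (within the scatter), stayed within the scatter.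

Compound 4 `N#CC1=C(NC(=O)c2ccc([N+](=O)[O-])cc2)N(c2ccc(S(N)(=O)=O)cc2)C2=C(C(=O)CCC2)C1c1ccc(Cl)cc1Cl` is not yet measured in this assay. Its structure differs from compound 3 by 4-nitrophenyl in place of 2-phenylethenyl on a carbonyl carbon. The step bearing most directly on this change is a number 5 percentage points higher from compound 2 to compound 3 (within the scatter), where one aromatic-bearing carbonyl group replaced another without a change beyond the scatter. The steps from compound 1 show that leaving cyclopropyl costs activity, but compound 4 keeps an aromatic group, so no further loss is expected. Compound 4 is therefore expected to give 42% in this assay, within 30% to 55%, a step of a number 3 percentage points lower from compound 3 to compound 4 (within the scatter) that is estimated to lie within the scatter.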

Compound 4, a percentage reported as activity, at one concentration (the size of the read-out at that concentration, not a potency): 70%
Compound 4: middle estimate off by 28 percentage points, on the low side; measured number outside the range, above it.
By their numbers in this assay, from the lowest: compounds 2 and 3 (each within the scatter of the next); then compounds 1 and 4 (each within the scatter of the next).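

In this assay the group on the carbonyl carbon proved more sensitive to the choice of aromatic group than compound 2 and compound 3 alone had suggested, with a number 25 percentage points higher from compound 3 to compound 4 (beyond the scatter) for 4-nitrophenyl in place of 2-phenylethenyl and a number 30 percentage points higher from compound 2 to compound 4 (beyond the scatter) for nitro in place of methyl on an aromatic carbon. The exchange of methyl for nitro on the same aromatic ring thus gave the largest step in this set, so what the ring carries matters here and not only the presence of a ring. Leaving cyclopropyl also no longer goes with a lower read-out in every case, since 4-nitrophenyl in its place gives a number 10 percentage points higher from compound 1 to compound 4 (within the scatter) and compound 4 goes against the pattern set by compound 2 and compound 3.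

The compounds shown leave open whether nitro is unique on this aromatic ring, or whether an amine, a carboxylic acid or a methoxy group in its place would give a similar read-out. Nothing in the data given bears on the reason for this result.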